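The compounds below may be only part of what the source reports. "The series", "measured", "known", "first", "only" and "open" are said of these compounds alone.

Measured values so far in a functional assay (Homo sapiens) for inhibition of Nucleic Acid, tested at 100 uM; a higher number here means more inhibition at the concentration tested (going by the name of the read-out), a lower number less inhibition:

compound 1, `[N-]=[N+]=Nc1nccc2c1ncn2C1O[C@H](CO)[C@@H](O)[C@H]1O`: 4%
compound 2, `[N-]=[N+]=Nc1[nH]ccc2ncnc1-2`: 20%
compound 3, `CNc1[nH]ccc2ncnc1-2`: 18%

Compound 2 and compound 3 share one core; compound 1 and the unmeasured compound 4, `CNc1nccc2c1ncn2C1O[C@H](CO)[C@@H](O)[C@H]1O`, share another. How the core of compound 1 differs from the core of compound 2 is not broken down here, the two differing in more than one place. In this assay compound 1 gives the lowest of the three numbers, with compound 3 the nearest and compound 2 the furthest, both gaps lying beyond the usual scatter of repeated measurements.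

Within the core of compound 2, the one change made so far is methylamino in place of azido on an aromatic carbon. It gave the step of a number 2 percentage points lower from compound 2 to compound 3 (within the scatter), which is within the scatter, so the methylamino and the azido on that aromatic carbon read as equivalent in this assay on this core.

Compound 4 carries exactly the same change on the core of compound 1: methylamino in place of azido on an aromatic carbon. The place description is the same word for word in both pairs. Among the compounds with values here, only one measured example of the change exists, so the expectation rests on one step alone. The expected step from compound 1 to compound 4 is a number 1 percentage points higher from compound 1 to compound 4 (within the scatter), taken to be flat because a number 2 percentage points lower from compound 2 to compound 3 (within the scatter) was within the scatter. For compound 4 the expected value is therefore estimated at 5%, with a range from -6% to 16%.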

Compound 4, a percentage reported as inhibition, at one concentration (the size of the read-out at that concentration, not a potency): 8%
Compound 4: middle estimate off by 3 percentage points, on the low side; measured number inside the range.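

In this assay, methylamino in place of azido on an aromatic carbon on the core of compound 1 gives a number 4 percentage points higher from compound 1 to compound 4 (within the scatter), so the two groups read as equivalent on this core, as they do on the core of compound 2. Set side by side, the two steps show no difference between the cores: the same change on two cores in this assay, a number 2 percentage points lower (within the scatter) from compound 2 to compound 3 and a number 4 percentage points higher (within the scatter) from compound 1 to compound 4, 6 percentage points apart, within the scatter of two such steps. Within the data shown here, this supports carrying the change between these two cores as a flat step, but it does not show that the change would stay flat on any other core, and a percentage at a single concentration gives no potency for either pair.

The compounds shown leave open whether a plain amine, a dimethylamino group or a longer alkylamino chain on that aromatic carbon would read like azido and methylamino or depart from them. They also leave open what each place in which the two cores differ contributes on its own.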